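The source may hold more compounds than are shown below. What is called first, only, known or untested is meant among the compounds shown, and "the series" means these compounds.

Compound 1 `CC(c1ccc(-c2ccccc2)c(F)c1)c1nnc2n1N=C(c1ccccc1)CS2`: 6700 nM
Compound 2 `CC(c1ccc(-c2ccccc2)c(F)c1)c1nnc2n1N=C(c1ccc(Cl)cc1)CS2`: 3900 nM
Compound 3 `CC(c1ccc(-c2ccccc2)c(F)c1)c1nnc2n1N=C(c1ccc(Br)cc1)CS2`: 5000 nM

All three were measured in a functional assay on Huh-7 cells (Homo sapiens) for inhibition, read by sulforhodamine B assay, with a stated time of 72 h; a lower number here means a stronger inhibitor, a higher number a weaker inhibitor. Compound 1 carries no substituent on the phenyl ring attached to the shared core, compound 2 a chloro group there, compound 3 a bromo group. Compound 3 stands close to both of the others: the step of a 1.3-fold lower number from compound 1 to compound 3 (0.13 log units; within the scatter) and the step of a 1.3-fold higher number from compound 2 to compound 3 (0.11 log units; within the scatter) are each within the scatter, as is the step of a 1.7-fold lower number from compound 1 to compound 2 (0.24 log units; within the scatter), so the three numbers cannot be told apart.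

Compound 4 `CC(c1ccc(-c2ccccc2)c(F)c1)c1nnc2n1N=C(c1ccc(F)cc1)CS2` differs from compound 3 in one place: fluoro in place of bromo on an aromatic carbon. Among the measured compounds shown here, no measured step exchanges one halogen for fluoro, but the steps that bear on it, from hydrogen to chloro, from hydrogen to bromo and from chloro to bromo, all stayed within the scatter. A fluoro group at the same place is therefore expected to leave this assay essentially unchanged, with no step beyond the scatter in either direction.

Compound 4 is accordingly estimated at 5500 nM, with a range from 2500 nM to 12000 nM. That estimate means an expected step of a 1.1-fold higher number from compound 3 to compound 4 (0.04 log units; within the scatter), expected to remain within the scatter.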

Compound 4, half-maximal inhibitory concentration: 4900 nM
Beside the measured number, compound 4's estimate is 1.1-fold (0.05 log units) above it; the range from low to high includes it.
By their numbers in this assay, from the lowest: compounds 2, 4, 3 and 1 (each within the scatter of the next).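

In this assay, fluoro on this aromatic carbon, para to a large group, adds a third halogen to a set of compounds that cannot be told apart: exchanging bromo gives a 1.0-fold lower number from compound 3 to compound 4 (0.01 log units; within the scatter), exchanging chloro gives a 1.3-fold higher number from compound 2 to compound 4 (0.10 log units; within the scatter), and exchanging hydrogen gives a 1.4-fold lower number from compound 1 to compound 4 (0.14 log units; within the scatter). Across all four compounds, no exchange at this place produces a step beyond the scatter, so the flat picture that rested on hydrogen, chloro and bromo now holds for fluoro as well. Nothing available accounts for this flat result.

Whether this place can move the number at all stays open, since the compounds shown do not tell how an amine, a carboxylic acid or a methoxy group there would read. The rest of the molecule is identical in all four compounds, so they also leave open what a change elsewhere would do.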